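Chloro for methyl on the phenyl ring of compound 3

The compounds below may be only part of what the source reports. "The series", "measured", "known", "first", "only" and "open" are said of these compounds alone.

Three measured members of the series share one core and a thiosemicarbazone link to a phenylpiperazine. Compound 1 `O=C1Nc2c(Br)cc(Br)cc2/C1=N/NC(=S)N1CCN(c2ccccc2)CC1` carries two bromines on the core and, in a functional assay on A549 cells (Homo sapiens) for inhibition, read by MTT assay, with a stated time of 72 h (on this read-out higher numbers stand for weaker inhibition and lower numbers for stronger inhibition), compound 1 gives 6110 nM. Compound 2 `O=C1Nc2cc(Cl)ccc2/C1=N/NC(=S)N1CCN(c2ccccc2)CC1` carries one chlorine on the core and an unsubstituted phenyl; in this assay compound 2 gives 27700 nM. Compound 3 `Cc1ccccc1N1CCN(C(=S)N/N=C2\C(=O)Nc3ccc(Cl)cc32)CC1` has a chlorine on the core at a different position from that in compound 2 and a methyl on the phenyl; in this assay compound 3 gives 6520 nM. Among the three numbers compound 3 stands second highest: its gap to compound 1 is within the scatter, its gap to compound 2 is beyond it, with compound 2 the higher number.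

Compound 4 `O=C1Nc2ccc(Cl)cc2/C1=N/NC(=S)N1CCN(c2ccccc2Cl)CC1` is the next member to be measured. The change from compound 3 is chloro in place of methyl on an aromatic carbon. Within the data shown here, no measured pair isolates this exchange; compound 2 differs from compound 4 at two sites, so its value alone cannot be read as this step. With nothing in the data to direct the step either way, the expectation is a change of no size beyond the scatter, a 1.1-fold higher number from compound 3 to compound 4 (0.03 log units; within the scatter). Compound 4 is therefore estimated at 7000 nM, with a range from 2500 nM to 22000 nM.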

Compound 4, half-maximal inhibitory concentration: 7920 nM
Estimate against measurement, compound 4: 1.1-fold (0.05 log units) below; the range from low to high includes it.
By their numbers in this assay, from the lowest: compounds 1, 3 and 4 (each within the scatter of the next); then compound 2.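

In this assay, among these compounds, the exchange of 2-methylphenyl for 2-chlorophenyl gives a 1.2-fold higher number from compound 3 to compound 4 (0.08 log units; within the scatter), the first step that isolates a single change. At this place, on an aromatic carbon ortho to a large group, methyl and chloro are not told apart by this read-out, so compound 3 and compound 4 stand as equivalent within the scatter. No measurement accompanying the result speaks to why the exchange leaves the number within the scatter.

On these data alone, one step at one place says nothing about the other places on the phenyl ring, and what a plain hydrogen at this place would give on the core shared by compound 3 and compound 4 stays open. Also open, as far as these compounds go, is whether this place stays as undiscriminating with a group unlike these two, such as a methoxy, an amine or a carboxylic acid, or with a longer chain such as propyl.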